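This account rests on a few compounds, and the source may have more. Where it says the series, first, only, none or still open, it means among the compounds named here.

Among the compounds with values here, in a functional assay on U-87MG ATCC cells (Homo sapiens) for antiproliferative activity (a higher number here means a weaker inhibitor, a lower number a stronger inhibitor), compound 2 `Cc1c2c(n3c1CCCN(C(=O)CN)[C@@H](C)[C@H](C)Nc1cc-3ccc1C(N)=O)CC(C)(C)CC2=O` gives 481 nM, the higher of the two numbers so far, while compound 1 `CC(=O)N1CCCc2c(C)c3c(n2-c2ccc(C(N)=O)c(c2)N[C@@H](C)[C@@H]1C)CC(C)(C)CC3=O` gives 29 nM. Within the data shown here, their one measured step, with amino in place of hydrogen, is large: a 17-fold higher number from compound 1 to compound 2 (1.22 log units; beyond the scatter). Compound 3 `Cc1c2c(n3c1CCCN(C(=O)CO)[C@@H](C)[C@H](C)Nc1cc-3ccc1C(N)=O)CC(C)(C)CC2=O` has hydroxy in place of amino on a saturated chain carbon bound to a carbonyl carbon. Among the measured compounds shown here, with only that single step as a guide, a partial return towards compound 1, at 29 nM, seems likely. In this assay the expected move is a 4.8-fold lower number from compound 2 to compound 3 (0.68 log units; beyond the scatter), a lower number beyond the scatter. For compound 3 the estimated value is 100 nM, with an expected range of 30 nM to 350 nM.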

Compound 3, half-maximal inhibitory concentration: 111 nM
For compound 3 the middle estimate is 1.1-fold (0.05 log units) below the measured one; low and high end bracket the measured number.
By their numbers in this assay, from the lowest: compound 1; then compound 3; then compound 2.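

Moving from amino to hydroxy on a saturated chain carbon bound to a carbonyl carbon gives, in this assay, a 4.3-fold lower number from compound 2 to compound 3 (0.64 log units; beyond the scatter), although both groups have the same count of heavy atoms, hydrogen-bond donors and acceptors, so this position distinguishes a nitrogen from an oxygen. Hydroxy still falls short of plain hydrogen, with a 3.8-fold higher number from compound 1 to compound 3 (0.58 log units; beyond the scatter), so neither group placed here matches compound 1. No measurement shown explains why the numbers move this way. Open, as far as these compounds go, is how a methoxy or a fluorine at this carbon would compare, and whether a longer chain carrying the hydroxy would close or widen the gap to compound 1.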